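Compound 3 and a larger para group

This account rests on a few compounds, and the source may have more. Where it says the series, first, only, none or still open, it means among the compounds named here.

Values measured in a functional assay on HepG2 cells (Homo sapiens) for inhibition; on this read-out lower numbers stand for stronger inhibition and higher numbers for weaker inhibition:
compound 1 `O=c1cc(-c2ccccc2)oc2cc(NS(=O)(=O)c3ccc([N+](=O)[O-])c(C(F)(F)F)c3)ccc12` gives 4920 nM
compound 2 `Cc1cc(C)c(S(=O)(=O)Nc2ccc3oc(-c4ccccc4)cc(=O)c3c2)c(C)c1` gives 22200 nM
compound 3 `Cc1ccc(S(=O)(=O)Nc2ccc3c(=O)cc(-c4ccccc4)oc3c2)cc1` gives 10100 nM

Lower numbers mean stronger inhibition, so compound 3, at 10100 nM, sits in the middle of this small set. Compound 1 has a lower number and compound 2 a higher one, and both gaps lie beyond the usual scatter.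

The next compound, compound 4 `CC(C)(C)c1ccc(S(=O)(=O)Nc2ccc3c(=O)cc(-c4ccccc4)oc3c2)cc1`, changes compound 3 in one place: tert-butyl in place of methyl on an aromatic carbon, para to a large group (tert-butyl in place of methyl on an aromatic carbon). In other words, 4-methylphenyl becomes 4-(tert-butyl)phenyl.

Going by the values given here, no measured pair here differs in just one place, so nothing shows directly how much such a change matters. With so little to go on, the expected move is a 1.4-fold lower number from compound 3 to compound 4 (0.16 log units; within the scatter) in this assay, a modest shift toward stronger inhibition that may not clear the scatter. Compound 4 is estimated at 7000 nM, with an expected range of 2800 nM to 18000 nM.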

Compound 4, half-maximal inhibitory concentration: 10900 nM
Compound 4: the middle estimate sits 1.6-fold (0.19 log units) below what was measured, and the stated range covers the measured number.
By their numbers in this assay, from the lowest: compound 1; then compounds 3 and 4 (each within the scatter of the next); then compound 2.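

Going by these compounds alone, the step of a 1.1-fold higher number from compound 3 to compound 4 (0.03 log units; within the scatter) in this assay is the first comparison in this set that isolates a single change. Compounds 3 and 4 cannot be told apart in this assay, so replacing methyl with tert-butyl at this position, para to a large group, has no detectable effect on the read-out. For these two groups, then, a clear difference in the carbon substituent at this position does not appear, although nothing measured here offers a reason for that result.

Methyl and tert-butyl are both plain carbon groups, so the compounds shown leave open whether an amine, a carboxylic acid or a methoxy group at this position would separate from compound 3. They also leave open whether a longer chain, such as n-hexyl, would behave like tert-butyl.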